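The source may hold more compounds than are shown below. What is called first, only, known or untested is meant among the compounds shown, and "the series" means these compounds.

Measured compounds in an assay on isolated protein for inhibition of ATP-dependent RNA helicase DDX3X (Homo sapiens), read by FRET, with stated times of 30 s and 40 min; on this read-out lower numbers stand for stronger inhibition and higher numbers for weaker inhibition:

compound 1, `CCOP(=O)(OCC)OCCc1cn(-c2ccc(NC(=O)Nc3ccccc3C)cc2)nn1`: 890 nM
compound 2, `O=C(Nc1ccc(-n2cc(CCO)nn2)cc1)Nc1ccccc1C(F)(F)F`: 11200 nM
compound 3, `CCCCc1cn(-c2ccc(NC(=O)Nc3cc(OC4CCOC4)ccc3C)cc2)nn1`: 100 nM

Compound 3 gives the lowest number of the three. Compound 1 sits well away from it, beyond the usual scatter, and compound 2 further still; no single-change comparison exists between any two of the measured compounds, so these three values are read only side by side, not as steps.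

Compound 4, `CCCCc1cn(-c2ccc(NC(=O)Nc3cc(OCOC)ccc3C)cc2)nn1`, is the unmeasured analogue of compound 3. The change is methoxymethyl in place of oxolan-3-yl on an oxygen on an aromatic ring. The oxolan-3-yl group of compound 3 with its five-membered non-aromatic ring gives way to methoxymethyl, which has no ring and fewer heavy atoms, while the single hydrogen-bond acceptor is kept. With nothing in the series to show how this position responds, the expectation is a small loss, about at the edge of the scatter, expressed as a 1.8-fold higher number from compound 3 to compound 4 (0.26 log units; within the scatter). For compound 4 in this assay the estimate is 180 nM, with a range from 70 nM to 450 nM.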

Compound 4, half-maximal inhibitory concentration: 820 nM
Compound 4: the middle estimate sits 4.6-fold (0.66 log units) below what was measured; the measured number lies above the stated range.
By their numbers in this assay, from the lowest: compound 3; then compounds 4 and 1 (each within the scatter of the next); then compound 2.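

In this assay, among the compounds shown here, the first single-change comparison gives an 8.2-fold higher number from compound 3 to compound 4 (0.91 log units; beyond the scatter) and so shows that inhibition responds to the group on this oxygen, even though oxolan-3-yl and methoxymethyl each carry one hydrogen-bond acceptor and no donor. Matching those counts therefore does not preserve the value here, and the step comes with the loss of the five-membered ring and a drop in heavy atoms, two differences that this single pair cannot separate. No measurement at hand accounts for the step.

Open, on these data alone, is whether the ring, its oxygen or the size of the group matters most, which cyclopentyl, oxan-4-yl or plain methyl on this oxygen would help to separate. Also open, as far as these compounds go, is whether a step of this size would hold on the core of compound 1.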